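The source may hold more compounds than are shown below. What is called first, only, known or untested is meant among the compounds shown, and "the series" means these compounds.

Working notes on the series.

Compound 1 `O=C(Nc1ccc(C(F)(F)F)cc1)NC1CCN(C(=O)C2=COCC2)CC1` is the lower of the two compounds measured in a physicochemical assay for solubility, read by mass spectrometry, in phosphate buffer, with a stated time of 24 h, at pH 3; on this read-out higher numbers stand for higher solubility and lower numbers for lower solubility: compound 1 gives 8.2 ug/mL. Within the data shown here, the other measured member, compound 2 `O=C(Nc1ccc(OC(F)(F)F)c(F)c1)NC1CCN(C(=O)N2CCOCC2)CC1`, gives 294 ug/mL in this assay; the two differ in more than one place, so no single step joins them, and only the two values themselves are on hand.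

Compound 3 `O=C(Nc1ccc(C(F)(F)F)cc1)NC1CCN(C(=O)c2cc[nH]c2)CC1` is not yet measured. It departs from compound 1 by one change (a group of 5 heavy atoms (4 carbon, 1 nitrogen; one five-membered aromatic ring with 1 hetero atom) in place of a group of 5 heavy atoms (4 carbon, 1 oxygen; one five-membered non-aromatic ring with 1 hetero atom), on a carbonyl carbon). The change swaps a five-membered non-aromatic ring with one hetero atom for a five-membered aromatic ring with one hetero atom at the carbonyl carbon, trading one hydrogen-bond acceptor for one hydrogen-bond donor. Among the measured compounds shown here, no measured pair shows such a swap, so there is nothing to anchor its size beyond the general position of compound 1.

On this basis compound 3 is expected to stay close to compound 1, with an estimated step of a 1.4-fold lower number from compound 1 to compound 3 (0.14 log units; within the scatter) that is not expected to exceed the scatter. The estimate for compound 3 in this assay is 6 ug/mL, with a range from 1.5 ug/mL to 25 ug/mL.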

Compound 3, solubility: 13 ug/mL
Estimate against measurement, compound 3: 2.2-fold (0.34 log units) below, and the stated range covers the measured number.
By their numbers in this assay, from the lowest: compounds 1 and 3 (each within the scatter of the next); then compound 2.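

In this assay the series now has its first step in a single place: 1H-pyrrol-3-yl on the carbonyl carbon, in place of the five-membered non-aromatic ring with 1 hetero atom, gives a 1.6-fold higher number from compound 1 to compound 3 (0.20 log units; within the scatter). At this position, a carbonyl carbon whose other neighbours are an amide-type nitrogen in a ring, exchanging a hydrogen-bond acceptor in the group for a hydrogen-bond donor leaves the two compounds within the scatter of each other, so the two groups cannot be told apart on this read-out. Nothing on hand explains this result.

Still open, going by these compounds, is whether a group of another kind at this carbonyl carbon, such as an amine or a carboxylic acid, would give a step beyond the scatter. Also open, on these data alone, is whether the same exchange would give a similar step on the core of compound 2.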